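Thiazole Series: Swapping Benzofuranyl for Fluorophenyl

The source may report more compounds than this note shows. Statements on the series, on what has been measured and on what is new or still open speak of the compounds shown alone.

Measured compounds:
compound 1 `O=C(O)CC1COc2cc(OCc3nnc(-c4ccccc4)o3)ccc21`, 1.54%
compound 2 `Cc1nc(-c2ccccc2)oc1COc1ccc2c(c1)OCC2CC(=O)O`, 7.15%
compound 3 `Cc1nc(-c2cc3ccccc3o2)sc1COc1ccc2c(c1)OCC2CC(=O)O`, 14.8%

All three share the same acid-bearing core and were examined in a functional assay on CHO cells for agonist activity at Free fatty acid receptor 1 (Homo sapiens), read by FLIPR and calcium flux, tested at 100 nM; a higher number here means a stronger effect of the compound at the concentration tested, a lower number a weaker effect. Compound 1 gives 1.54%, compound 2 gives 7.15%, and compound 3 gives 14.8%. Among these three numbers compound 3 carries the largest one; its gap to compound 1 lies beyond the usual scatter, whereas the gap to compound 2 stays within the scatter, so compound 2 and compound 3 cannot be ranked against each other.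

The next compound, compound 4 `Cc1nc(-c2ccc(F)cc2)sc1COc1ccc2c(c1)OCC2CC(=O)O`, has not been measured. It differs from compound 3 in one place: 4-fluorophenyl in place of 1-benzofuran-2-yl on an aromatic carbon. For the measured compounds named here, no measured pair in this set isolates that change, so the size of the step is open. Compound 2, which bears a plain phenyl on its heteroaromatic ring, gives 7.15%, and compound 3 gives 14.8%; on that basis a modest downward step or none beyond the scatter is expected. The estimate for compound 4 in this assay is 9%, spanning 2% to 20%, which is expected to mean a step of a number 5.8 percentage points lower from compound 3 to compound 4 (within the scatter).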

Compound 4, a percentage reported as activity, at one concentration (the size of the read-out at that concentration, not a potency): 61.6%
Beside the measured number, compound 4's estimate is 52.6 percentage points below it; measured number above the stated range.
By their numbers in this assay, from the lowest: compounds 1, 2 and 3 (each within the scatter of the next, the first and the last beyond it); then compound 4.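

In this assay, the group on this aromatic carbon of the five-membered aromatic ring with 1 nitrogen and 1 sulfur turns out to matter greatly: 4-fluorophenyl in place of 1-benzofuran-2-yl gives a number 46.8 percentage points higher from compound 3 to compound 4 (beyond the scatter). For the compounds shown here, this is the only pair in the set that differs in one place, and it shows that a change at this position alone, with the rest of the molecule kept, can move the read-out far beyond the scatter. No measurement at hand gives a cause for the size of this step.

The change removes a five-membered aromatic ring and adds a fluorine in one move, so the compounds shown cannot say how much of the step belongs to each; a plain phenyl on this same carbon, with the rest of compound 4 kept, would separate the two. They also leave open whether the fluorine is needed at all in this place, or whether a 4-chlorophenyl or a 4-methoxyphenyl group on the same carbon would give a comparable read-out in this assay.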